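Swapping the linker and aryl group on a benzimidazole acid

A few compounds are considered here, and "the series" means these few. Any claim that something is new, unique, unknown or untested is made for them only; others in the source may bear on it.

Compound 3 `Cn1c(Cc2ccc3c(c2)OCC3)nc2cc(O[C@H]3CC[C@@H](C(=O)O)CC3)ccc21` sits at the highest of the two plain numbers in an assay on isolated protein for inhibition of Long-chain-fatty-acid--CoA ligase 1 (Mus musculus), read by mass spectrometry, with a stated time of 90 min, in the presence of a further agent that is not named here (on this read-out higher numbers stand for weaker inhibition and lower numbers for stronger inhibition), where compound 3 gives 36 nM. Its nearest neighbour is compound 1 `Cc1cccc(Cc2nc3cc(O[C@H]4CC[C@@H](C(=O)O)CC4)ccc3n2C)c1`, which gives 30 nM; the gap a 1.2-fold higher number from compound 1 to compound 3 (0.08 log units; within the scatter) is within the usual scatter. Compound 2 `Cn1c(Cc2cccnc2)nc2cc(O[C@H]3CC[C@@H](C(=O)O)CC3)ccc21` gives only a limit of the assay, > 200000 nM. Moving to compound 4 `Cc1cccc(COc2nc3cc(O[C@H]4CC[C@@H](C(=O)O)CC4)ccc3n2C)c1` means (a group of 9 heavy atoms (8 carbon, 1 oxygen; one six-membered aromatic ring of carbon only) in place of a group of 10 heavy atoms (9 carbon, 1 oxygen; one five-membered non-aromatic ring with 1 hetero atom, one six-membered aromatic ring of carbon only), on an aromatic carbon). The step of a 1.2-fold higher number from compound 1 to compound 3 (0.08 log units; within the scatter) shows that exchanging the two aryl groups changes little. Within the data shown here, no measured pair, however, tests the change of the linking atom on that aromatic carbon, so the expectation is uncertain. Compound 4 is estimated at 80 nM, with a range from 15 nM to 600 nM, so the expected step of a 2.2-fold higher number from compound 3 to compound 4 (0.35 log units; beyond the scatter) is small.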

Compound 4, half-maximal inhibitory concentration: 8100 nM
The estimate for compound 4 lay 100-fold (2.01 log units) below the measured number; measured number outside the range, above it.
By their numbers in this assay, from the lowest: compounds 1 and 3 (each within the scatter of the next); then compound 4. At a limit, above all of these: compound 2.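

Compound 1 and compound 4 differ only in that (3-methylbenzyl)oxy replaces 3-methylbenzyl, so the linking atom alone gives a large step: a 270-fold higher number from compound 1 to compound 4 (2.43 log units; beyond the scatter). Compound 3 also differs in its aromatic group, and its step is of similar size: a 230-fold higher number from compound 3 to compound 4 (2.35 log units; beyond the scatter). Compound 4 still improves on compound 2, whose value is only a limit: an at least 24-fold lower number from compound 2 to compound 4 (1.39 log units; beyond the scatter).

Going by these compounds, whether an amine nitrogen or a longer chain at this place would behave like the chain carbon or like the oxygen stays open. The data shown give no measured reason for the effect of the oxygen.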